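The source may report more compounds than this note shows. Statements on the series, on what has been measured and on what is new or still open speak of the compounds shown alone.

Values in a functional assay on MCF7 cells (Homo sapiens) for antiproliferative activity, read by sulforhodamine B assay, with a stated time of 72 h; on this read-out lower numbers stand for stronger inhibition and higher numbers for weaker inhibition:
- Compound 1 `Cc1ccc(S(=O)(=O)Nc2cc(SCC(=O)N[C@@H](CC(C)C)B(O)O)c(O)c3ccccc23)cc1`: 12800 nM
- Compound 2 `CC(=O)Nc1ccc(S(=O)(=O)Nc2cc(SCC(=O)N[C@@H](CC(C)C)B(O)O)c(O)c3ccccc23)cc1`: 8660 nM
- Compound 3 `Cc1ccc(S(=O)(=O)Nc2cc(SCCC(=O)N[C@@H](CC(C)C)B(O)O)c(O)c3ccccc23)cc1`: 6940 nM

On these numbers, compound 3, at 6940 nM, cannot be ranked against the other two, as all three values lie within the usual scatter of one another. Such scatter is the variation expected when the same measurement is simply repeated.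

Compound 4 `CC(C)C[C@H](NC(=O)CCSc1cc(NS(=O)(=O)c2ccc(Cl)cc2)c2ccccc2c1O)B(O)O` has not yet been measured. Its structure departs from that of compound 3 by one small swap: chloro in place of methyl on an aromatic carbon. In words, this is chloro in place of methyl on an aromatic carbon, turning a 4-methylphenyl into a 4-chlorophenyl.

Two measured steps offer guidance. The closer one also replaces this methyl, with acetamido instead of chloro, and gives a 1.5-fold lower number from compound 1 to compound 2 (0.17 log units; within the scatter). The other alters the chain on the sulfur and leaves the methyl untouched, giving a 1.8-fold lower number from compound 1 to compound 3 (0.27 log units; within the scatter). Within the data shown here, neither step goes beyond the scatter, and no measured compound carries chloro, so the evidence is indirect. No clear shift in either direction is therefore expected in this assay.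

The expected change is a 1.2-fold lower number from compound 3 to compound 4 (0.06 log units; within the scatter), a step estimated to stay within the scatter. For compound 4, the estimated value is 6000 nM, with an expected range from 2500 nM to 14000 nM.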

Compound 4, half-maximal inhibitory concentration: 6910 nM
For compound 4 the middle estimate is 1.2-fold (0.06 log units) below the measured one; the range from low to high includes it.
By their numbers in this assay, from the lowest: compounds 4, 3, 2 and 1 (each within the scatter of the next).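

In this assay, placing chloro where compound 3 has methyl, on the aromatic carbon para to a large group, gives a 1.0-fold lower number from compound 3 to compound 4 (0.00 log units; within the scatter), so the 4-chlorophenyl and 4-methylphenyl compounds cannot be told apart here. Among these compounds, until now, acetamido was the only replacement for this methyl, with a 1.5-fold lower number from compound 1 to compound 2 (0.17 log units; within the scatter), and that pair carries the shorter chain on the sulfur, so this is the first such replacement seen on the longer chain and the first with a halogen. Across these two pairs, both replacements of the methyl stay within the scatter, and no data on hand offer an explanation for this result.

On these data alone, two replacements are a small sample, so it remains open whether a different group at this position, such as an amine, a carboxylic acid or a methoxy group, would also stay within the scatter or would move the number beyond it. As far as these compounds go, it is also open whether a longer chain at the same position would fit this picture, and whether the acetamido group would give a similar result on the longer chain on the sulfur.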